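Notes on replacing the benzimidazole in a hedgehog inhibitor series

The source may hold more compounds than are shown below. What is called first, only, known or untested is meant among the compounds shown, and "the series" means these compounds.

Compound 1 `Cc1nc(C(F)(F)F)ccc1C(=O)Nc1ccc(Cl)c(-c2nc3ccccc3[nH]2)c1` is the reference point of this small set. Among the measured compounds shown here, in an assay on C3H 10T1/2 cells for inhibition of Sonic hedgehog protein (Mus musculus), read by a luciferase reporter (a lower number here means a stronger inhibitor, a higher number a weaker inhibitor), compound 1 gives 12 nM, the lowest of the three numbers so far. Compound 2 `Cc1nc(C(F)(F)F)ccc1C(=O)Nc1ccc(Cl)c(-c2cc3ccccc3[nH]2)c1` gives 500 nM, and compound 3 `Cc1nc(C(F)(F)F)ccc1C(=O)Nc1ccc(Cl)c(C(=O)Nc2ccccc2)c1` gives 140 nM. Both known variations at this position weaken binding: a 42-fold higher number from compound 1 to compound 2 (1.62 log units; beyond the scatter) and a 12-fold higher number from compound 1 to compound 3 (1.07 log units; beyond the scatter); between the two replacements, a 3.6-fold lower number from compound 2 to compound 3 (0.55 log units; beyond the scatter).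

Compound 4 `Cc1nc(C(F)(F)F)ccc1C(=O)Nc1ccc(Cl)c(-c2ccn(C)n2)c1` changes the same position. The difference from compound 1 is 1-methyl-1H-pyrazol-3-yl in place of 1H-benzimidazol-2-yl on an aromatic carbon. Both measured steps that touch this position bear on the new one, and both were large in the weakening direction, so a step of similar size is expected from compound 1 to compound 4, with the exact magnitude uncertain since neither measured step introduces a group of this kind. The expected step is a 13-fold higher number from compound 1 to compound 4 (1.10 log units; beyond the scatter).

Compound 4 is therefore expected to show a weaker result than compound 1, estimated at 150 nM in this assay, with a range from 40 nM to 600 nM.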

Compound 4, half-maximal inhibitory concentration: 550 nM
The estimate for compound 4 lay 3.7-fold (0.56 log units) below the measured number, and the stated range covers the measured number.
By their numbers in this assay, from the lowest: compound 1; then compound 3; then compounds 2 and 4 (each within the scatter of the next).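

In this assay the 1-methyl-1H-pyrazol-3-yl group gives a 46-fold higher number from compound 1 to compound 4 (1.66 log units; beyond the scatter) even though it keeps a five-membered aromatic ring with 2 hetero atoms, as the 1H-benzimidazol-2-yl group does, so that ring alone does not preserve the low number of compound 1. The replacement drops the six-membered aromatic ring of carbon only and has 0 hydrogen-bond donors, yet its result cannot be told apart from that of the 1H-indol-2-yl group, with a 1.1-fold higher number from compound 2 to compound 4 (0.04 log units; within the scatter) as the printed step between two quite different groups. The phenylcarbamoyl group now stands apart from both of these, with a 3.9-fold higher number from compound 3 to compound 4 (0.59 log units; beyond the scatter) placing compound 3 as the best of the three replacements, though still short of compound 1.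

Nothing available explains any of these steps, and the loss of the hydrogen-bond donor cannot be separated from the loss of the six-membered ring in this comparison. Open, as far as these compounds go, is whether the 1H-pyrazol-3-yl group without its methyl, or a 1H-imidazol-2-yl group, would recover any of the lost ground at this position on the shared core.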